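Maleimide series: amide-nitrogen aryl swap, ECa-109 antiproliferation

The source may hold more compounds than are shown below. What is called first, only, known or untested is meant among the compounds shown, and "the series" means these compounds.

Measured so far:
compound 1 `CN(C)CCCn1nc(C2=C(c3cn(C)c4ccccc34)C(=O)N(c3ccccc3)C2=O)c2cccnc21` — 5840 nM
compound 2 `Cn1cc(C2=C(c3nn(CCCN4CCCCC4)c4ncccc34)C(=O)N(c3cccc4ccccc34)C2=O)c2ccccc21` — 1830 nM

Both compounds were run in a functional assay on ECa-109 cells (Homo sapiens) for antiproliferative activity, read by MTT assay, with a stated time of 48 h; a lower number here means a stronger inhibitor, a higher number a weaker inhibitor. Compound 2 gives the lowest of the two numbers; the nearest is compound 1, whose value is higher by a margin beyond the usual scatter. Among the measured compounds shown here, compound 1 and compound 2 differ from each other in more than one place, so no single step between measured compounds is available.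

Compound 3 `Cn1cc(C2=C(c3nn(CCCN4CCCCC4)c4ncccc34)C(=O)N(c3ccccc3)C2=O)c2ccccc21` has not yet been measured. It departs from compound 2 by phenyl in place of naphthalen-1-yl on an amide-type nitrogen in a ring. Compound 3 thereby carries the same phenyl on the amide-type nitrogen as compound 1, while keeping the rest of compound 2.

For the measured compounds named here, with no measured step for this exact change, the expectation rests on where compound 1 and compound 2 sit. Compound 3 is expected to land between them, most likely somewhat weaker than compound 2, with an estimated step of a 1.9-fold higher number from compound 2 to compound 3 (0.28 log units; within the scatter) that may not exceed the scatter. The estimated value for compound 3 is 3500 nM, with a range from 1500 nM to 8000 nM.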

Compound 3, half-maximal inhibitory concentration: 12300 nM
Compound 3: the middle estimate sits 3.5-fold (0.55 log units) below what was measured, outside the stated range (above it).
By their numbers in this assay, from the lowest: compound 2; then compound 1; then compound 3.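

In this assay, the amide-type nitrogen of the five-membered non-aromatic ring is a position that responds clearly: phenyl in place of naphthalen-1-yl gives a 6.7-fold higher number from compound 2 to compound 3 (0.83 log units; beyond the scatter), so in this pair the larger aryl group carries the lower number. Compound 3 also isolates the end of the chain, which the earlier pair could not do, since compound 1 and compound 2 differ in more than one place: piperidin-1-yl in place of dimethylamino gives a 2.1-fold higher number from compound 1 to compound 3 (0.32 log units; beyond the scatter), a smaller step than the aryl swap, though still beyond the scatter. Nothing at hand accounts for either step.

Still open, from the compounds shown here alone, is whether the lower number in compound 2 follows from the second aromatic ring as such or from the naphthalen-1-yl group specifically, a question that naphthalen-2-yl or benzyl on the amide-type nitrogen would address. Also open, going by these compounds, is whether the chain-end step holds when naphthalen-1-yl replaces phenyl, as a dimethylamino partner of compound 2 would show, and how morpholin-4-yl would read at the end of the chain.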